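A Hydrazone Aryl Swap on a Triazolylpyridine Ether

The compounds below may be only part of what the source reports. "The series", "measured", "known", "first", "only" and "open" are said of these compounds alone.

Compound 2 `CN(C)CCn1cnnc1-c1cc(Oc2ccc(NC(=O)N/N=C/c3cc(Br)c(O)c(Br)c3)cc2F)ccn1` gives the higher of the two numbers obtained in a functional assay on NCI-H460 cells (Homo sapiens) for cytotoxicity, read by MTT assay, with a stated time of 72 h (on this read-out higher numbers stand for weaker inhibition and lower numbers for stronger inhibition), namely 3760 nM. Its nearest neighbour is compound 1 `CN(C)CCn1cnnc1-c1cc(Oc2ccc(NC(=O)N/N=C/c3ccccc3)cc2F)ccn1`, which in this assay gives 1780 nM; the change from the plain phenyl to the 3,5-dibromo-4-hydroxyphenyl brought a 2.1-fold higher number from compound 1 to compound 2 (0.32 log units; beyond the scatter). Compound 3 `COc1ccc(/C=N/NC(=O)Nc2ccc(Oc3ccnc(-c4nncn4CCN(C)C)c3)c(F)c2)cc1O` differs from compound 2 by 3-hydroxy-4-methoxyphenyl in place of 3,5-dibromo-4-hydroxyphenyl on a carbon with a double bond to nitrogen. Within the data shown here, no measured step covers this exact swap; the only step on the same carbon, a 2.1-fold higher number from compound 1 to compound 2 (0.32 log units; beyond the scatter), shows that decorating that ring moved the number modestly upward. Removing the two bromines while keeping one hydroxyl and adding a methoxy could plausibly land between compound 1 and compound 2. Compound 3 is therefore expected to give a 1.5-fold lower number from compound 2 to compound 3 (0.18 log units; within the scatter), with an estimated value of 2500 nM and a likely range from 900 nM to 7000 nM in this assay.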

Compound 3, half-maximal inhibitory concentration: 620 nM
Beside the measured number, compound 3's estimate is 4.0-fold (0.61 log units) above it, and the stated range ends above it.
By their numbers in this assay, from the lowest: compound 3; then compound 1; then compound 2.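

On the carbon with a double bond to nitrogen, decorating the phenyl ring does not only raise the number in this assay: 3-hydroxy-4-methoxyphenyl gives a 2.9-fold lower number from compound 1 to compound 3 (0.46 log units; beyond the scatter), the opposite direction to the one the 3,5-dibromo-4-hydroxyphenyl group had shown. The exchange of one decorated ring for the other gives a 6.1-fold lower number from compound 2 to compound 3 (0.78 log units; beyond the scatter), although both groups have the same heavy-atom count, so that count alone does not set the number at this position. No available evidence accounts for this order of the three rings.

As far as these compounds go, whether the hydroxyl, the methoxy or the two together carry the shift remains open. So does the outcome of placing a different group on this ring, such as a dimethylamino group or a carboxylic acid.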